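The source may report more compounds than this note shows. Statements on the series, on what has been measured and on what is new or still open speak of the compounds shown alone.

Three compounds built on one shared core have so far been examined in a functional assay on SH-SY5Y cells (Homo sapiens), read by MTT assay, with a stated time of 24 h; on this read-out lower numbers stand for an effect already at smaller amounts and higher numbers for an effect only at larger amounts of compound. Compound 1 `COc1ccc(Cl)cc1N(CC(=O)N(C1CCCCC1)C1CCCCC1)S(=O)(=O)c1ccccc1` gives 14300 nM in this assay. Compound 2 `COc1ccc(Cl)cc1N(CC(=O)N1CCCCC1)S(=O)(=O)c1ccccc1` gives 14500 nM in this assay; among the two numbers shown it stands highest, with compound 1 as its nearest neighbour at a gap within the scatter. Compound 3 `COc1ccc(Cl)cc1N(CC(=O)Nc1ccc(Cl)cc1)S(=O)(=O)c1ccccc1` returns only a limit of the assay, > 20000 nM, rather than a number. Among the compounds with values here, the one measured step, an at least 1.3-fold higher number from compound 2 to compound 3 (0.13 log units; that floor lies within the scatter), has a floor that lies within the scatter, so its true size is open; the limit of > 20000 nM in this assay, at which 1 of the 3 values shown sits, marks how far that step is known.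

The compound now in question is compound 4 `COc1ccc(Cl)cc1N(CC(=O)Nc1ccc([N+](=O)[O-])cc1)S(=O)(=O)c1ccccc1`. It differs from compound 2 by (4-nitrophenyl)amino in place of piperidin-1-yl on a carbonyl carbon. Within the data shown here, the only measured step that bears on this change is an at least 1.3-fold higher number from compound 2 to compound 3 (0.13 log units; that floor lies within the scatter), which likewise exchanges piperidin-1-yl for a substituted phenylamino group and ends at a limit. The account therefore expects compound 4 to move in the same direction, toward a higher number, with a fair chance that this assay again reports only a limit. The expected step is a 1.7-fold higher number from compound 2 to compound 4 (0.24 log units; within the scatter). The estimated value for compound 4 is 25000 nM, between 12000 nM and 60000 nM.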

Compound 4, half-maximal effective concentration: 8210 nM
Beside the measured number, compound 4's estimate is 3.0-fold (0.48 log units) above it; the measured number lies below the stated range.
By their numbers in this assay, from the lowest: compounds 4, 1 and 2 (each within the scatter of the next). At a limit, above all of these: compound 3.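

In this assay, the step to a phenylamino group on this carbonyl carbon does not have to end at a limit, as compound 3 alone had left possible: the change to (4-nitrophenyl)amino gives a 1.8-fold lower number from compound 2 to compound 4 (0.25 log units; within the scatter), so this group stands level with piperidin-1-yl within the scatter. The group on the aromatic carbon turns out to count for more than the exchange on the carbonyl carbon, since nitro in place of chloro gives an at least 2.4-fold lower number from compound 3 to compound 4 (0.38 log units; beyond the scatter), the only step shown here that lies beyond the scatter. That size is only a floor, and compound 3 remains at a limit of the assay: the limit of > 20000 nM in this assay, at which 1 of the 4 values shown sits.

Whether an amine, a carboxylic acid or a simple methoxy group on that aromatic carbon would side with nitro or with chloro remains open, so the two groups shown there give a single contrast and no trend. Also open, on these data alone, is how a phenylamino group with only hydrogen on its ring would stand against piperidin-1-yl on the carbonyl carbon.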